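This account rests on a few compounds, and the source may have more. Where it says the series, first, only, none or still open, it means among the compounds named here.

Among the measured compounds shown here, in a functional assay on U-87MG ATCC cells (Homo sapiens) for cytotoxicity, read by MTT assay, with a stated time of 72 h (on this read-out lower numbers stand for stronger inhibition and higher numbers for weaker inhibition), compound 3 `COc1ccc(/C=N/NC(=O)Nc2ccc(Oc3ccnc(-c4nncn4CCN(C)C)c3)c(F)c2)c(OC)c1` gives 12600 nM, the only actual number among the three measured compounds. Compound 1 `CN(C)CCn1cnnc1-c1cc(Oc2ccc(NC(=O)N/N=C/c3ccc(O)c(O)c3)cc2F)ccn1` reaches only the limit > 100000 nM. Compound 2 `CN(C)CCn1cnnc1-c1cc(Oc2ccc(NC(=O)N/N=C/c3cc(Br)c(O)c(Br)c3)cc2F)ccn1` likewise reaches only the limit > 100000 nM. Both therefore sit at the limit of > 100000 nM in this assay, at which 2 of the 3 values shown sit. The steps of an at least 7.9-fold lower number from compound 1 to compound 3 (0.89 log units; beyond the scatter) and an at least 7.9-fold lower number from compound 2 to compound 3 (0.89 log units; beyond the scatter) show that replacing a hydroxyl-bearing ring with 2,4-dimethoxyphenyl lowered the number by at least a modest amount. Compound 4 `COc1ccc(/C=N/NC(=O)Nc2ccc(Oc3ccnc(-c4nncn4CCN(C)C)c3)c(F)c2)cc1O` differs from compound 3 by 3-hydroxy-4-methoxyphenyl in place of 2,4-dimethoxyphenyl on a carbon with a double bond to nitrogen, which brings a hydroxyl back onto the ring. The expected step in this assay is a 3.2-fold higher number from compound 3 to compound 4 (0.50 log units; beyond the scatter), a rise back toward the limit, though its exact size is uncertain. Compound 4 is estimated at 40000 nM, between 15000 nM and 100000 nM.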

Compound 4, half-maximal inhibitory concentration: > 100000 nM
Compound 4 was reported as a limit; the forecaster's own chance of this, stated with the estimate: 30%; middle value at least 2.5-fold (0.39 log units) from the limit.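

In this assay the change to 3-hydroxy-4-methoxyphenyl gives an at least 7.9-fold higher number from compound 3 to compound 4 (0.89 log units; beyond the scatter), a step read against a limit. One hydroxyl on the ring, with a methoxy kept, thus gives the same limit as the rings of compound 1 and compound 2, and compound 3 remains the only one of the four with no ring hydroxyl and a real number. The steps among compound 1, compound 2 and compound 4 cannot be read, because all three stand at: the limit of > 100000 nM in this assay, at which 3 of the 4 values shown sit.

Compound 4 also differs from compound 3 in the methoxy pattern, so the hydroxyl alone cannot be singled out. From the compounds shown here alone, whether an amino group in place of that hydroxyl would give a readable number remains open.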